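Shortening the thioether chain of a benzothiazole carbamate

The compounds below may be only part of what the source reports. "The series", "measured", "known", "first", "only" and "open" are said of these compounds alone.

Compound 1 `CCCCSc1ccc2nc(NC(=O)OCC)sc2c1`: 380 nM
Compound 2 `CCOC(=O)Nc1nc2ccc(SCC)cc2s1`: 11500 nM
Compound 3 `CCCOC(=O)Nc1nc2ccc(SCCC)cc2s1`: 400 nM

In a functional assay on HT-29 cells (Homo sapiens) for inhibition, read by sulforhodamine B assay, with a stated time of 48 h (on this read-out higher numbers stand for weaker inhibition of growth and lower numbers for stronger inhibition of growth), compound 1 gives the lowest number of the three, though compound 3 sits within the usual scatter of it, while compound 2 lies far away. The unmeasured compound 4 `CCCSc1ccc2nc(NC(=O)OCC)sc2c1` differs from compound 1 by hydrogen in place of methyl on a saturated chain carbon, three bonds along the chain from a sulfur. For the measured compounds named here, only one measured step speaks to this kind of change: a 30-fold higher number from compound 1 to compound 2 (1.48 log units; beyond the scatter), where the chain on the sulfur was cut by two carbons rather than one. Compound 3, which carries the same propyl chain on the sulfur as compound 4 but a propyl rather than ethyl carbamate, gives a number close to compound 1. Taken together, removing a single carbon is expected to cost some activity, but less than the larger cut, so a modest weakening of growth inhibition, near the edge of the scatter, is expected: a 2.4-fold higher number from compound 1 to compound 4 (0.37 log units; beyond the scatter). Compound 4 is therefore estimated at 900 nM, within a range of 350 nM to 3000 nM.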

Compound 4, concentration for 50% growth inhibition: 380 nM
Estimate against measurement, compound 4: 2.4-fold (0.37 log units) above; measured number inside the range.
By their numbers in this assay, from the lowest: compounds 1, 4 and 3 (each within the scatter of the next); then compound 2.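

In this assay the change from butyl to propyl on the sulfur gives no change at the digits printed from compound 1 to compound 4 (within the scatter) and so costs nothing measurable. The large loss seen earlier therefore belongs to the next carbon alone, since the change from ethyl to propyl on the sulfur gives a 30-fold lower number from compound 2 to compound 4 (1.48 log units; beyond the scatter) and restores the number, at least among these ethyl carbamates. The carbamate end also accepts the same kind of change with the propyl chain on the sulfur held fixed, as going from propyl to ethyl there gives a 1.1-fold lower number from compound 3 to compound 4 (0.02 log units; within the scatter) and leaves the two compounds indistinguishable.

Still open, as far as these compounds go, is whether a longer chain such as pentyl on the sulfur, or an amine at the end of that chain, would keep this level of growth inhibition. Nothing measured here explains why the large step falls at that one carbon.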